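Chloro for Methyl on the Anilide Ring of Compound 3

The source may hold more compounds than are shown below. What is called first, only, known or untested is meant among the compounds shown, and "the series" means these compounds.

Compound 3 `CCN(CC)CCCOc1cc2ncnc(Nc3nc4ccc(C(=O)Nc5c(C)cccc5C)cc4s3)c2cc1OC` gives 23700 nM in a functional assay on U-937 cells (Homo sapiens) for cytotoxicity, read by WST assay, with a stated time of 72 h (a lower number here means a stronger inhibitor, a higher number a weaker inhibitor), the highest of the three numbers recorded, although its gap to compound 2 lies within the scatter. Compound 2 `COc1cc2c(Nc3nc4ccc(C(=O)Nc5c(C)cccc5C)cc4s3)ncnc2cc1OCCCN1CCCC1` gives 18900 nM, and the step of a 1.3-fold higher number from compound 2 to compound 3 (0.10 log units; within the scatter) concerns only the amine on the chain. Compound 1 `COc1cc2c(Nc3nc4ccc(C(=O)Nc5c(C)cccc5Cl)cc4s3)ncnc2cc1OCCCN1CCCCC1C` gives 7000 nM, the lowest of the three. Compound 4 `CCN(CC)CCCOc1cc2ncnc(Nc3nc4ccc(C(=O)Nc5c(C)cccc5Cl)cc4s3)c2cc1OC` differs from compound 3 by chloro in place of methyl on an aromatic carbon. Among the compounds with values here, no measured pair differs in this place alone: compound 1 carries the chloro group, but it also carries a different amine on the chain, so its gap to compound 3 cannot be credited to the chloro group by itself. What compound 1 and compound 3 show together leaves room for a lower number with chloro, yet nothing isolates that effect. For compound 4 a modest move toward a lower number is expected, a 1.6-fold lower number from compound 3 to compound 4 (0.20 log units; within the scatter), which may well stay within the scatter. Compound 4 is estimated at 15000 nM, with a range from 6000 nM to 35000 nM.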

Compound 4, half-maximal inhibitory concentration: 7300 nM
Estimate against measurement, compound 4: 2.1-fold (0.31 log units) above; the measured number falls inside the stated range.
By their numbers in this assay, from the lowest: compounds 1 and 4 (each within the scatter of the next); then compounds 2 and 3 (each within the scatter of the next).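

With the diethylamino chain held fixed, the exchange of methyl for chloro on the anilide ring can be read alone in this assay and gives a 3.2-fold lower number from compound 3 to compound 4 (0.51 log units; beyond the scatter) as a step that clears the scatter, so this aromatic carbon responds to the change. Once chloro is present, the amine matters little across this pair, with a 1.0-fold higher number from compound 1 to compound 4 (0.02 log units; within the scatter) as the reading, and the same holds among the 2,6-dimethylphenyl compounds, where the reading is a 1.3-fold higher number from compound 2 to compound 3 (0.10 log units; within the scatter) and also lies within the scatter. No measurement offered here accounts for the step.

Going by these compounds, whether fluoro or bromo on this carbon would read the same remains open, as does the effect of a second chloro giving a 2,6-dichlorophenyl group. On these data alone, it is also open whether the step carries over to the pyrrolidin-1-yl chain.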